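The source may hold more compounds than are shown below. What is called first, only, known or untested is meant among the compounds shown, and "the series" means these compounds.

Of the compounds shown here, two sharing one core have been measured. In an assay on isolated protein for inhibition of Indoleamine 2,3-dioxygenase 1 (Homo sapiens), read by colorimetric assay, with stated times of 10 min and 30 min, tested at 100 uM (on this read-out lower numbers stand for less inhibition and higher numbers for more inhibition at the one concentration tested (going by the name of the read-out)), compound 1 `Fc1ccccc1-c1c[nH]c(=S)s1` gives 29%. In this assay compound 2 `S=c1[nH]cc(-c2cccc(Br)c2)s1` gives 48%, the higher of the two numbers, a gap beyond the usual scatter. Compound 3 `S=c1[nH]cc(-c2ccccc2)s1` has not been measured yet; it differs from compound 2 by hydrogen in place of bromo on an aromatic carbon. Because compound 1 gives 29% without the bromo group, compound 3 is expected to show a downward step of a number 18 percentage points lower from compound 2 to compound 3 (beyond the scatter) from compound 2. Compound 3 is estimated to give 30%, expected to lie between 10% and 55%.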

Compound 3, a percentage reported as inhibition, at one concentration (the size of the read-out at that concentration, not a potency): 16%
Beside the measured number, compound 3's estimate is 14 percentage points above it, within the range that was stated.
By their numbers in this assay, from the lowest: compound 3; then compound 1; then compound 2.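

Hydrogen in place of bromo on the aromatic carbon gives a number 32 percentage points lower from compound 2 to compound 3 (beyond the scatter) in this assay, and hydrogen in place of fluoro gives a number 13 percentage points lower from compound 1 to compound 3 (beyond the scatter). Compound 3 supplies the first comparison without a halogen on this ring: among these compounds, both fluoro in compound 1 and bromo in compound 2 go with a higher number than hydrogen. The step from bromo is the larger of the two.

No measurement here gives a reason for these steps. On these data alone, whether an amine or a carboxylic acid in place of the bromo would also give a higher number than hydrogen stays open.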